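Aryl change on the ring nitrogen

The compounds below may be only part of what the source reports. "The series", "measured", "known", "first", "only" and "open" are said of these compounds alone.

In a functional assay on HL-60 cells (Homo sapiens) for inhibition, read by MTT assay, with a stated time of 72 h (a higher number here means a weaker inhibitor, a lower number a stronger inhibitor), two compounds with a shared core have been measured. Compound 1 `COc1cccc(N2CCN(C(=O)c3oc(C)nc3-c3ccccc3F)CC2)c1` gives 56.1 nM and compound 2 `Cc1ccc(C)c(N2CCN(C(=O)c3oc(C)nc3-c3ccccc3F)CC2)c1` gives 319 nM, so compound 2 is the weaker inhibitor and has the higher of the two numbers. Within the data shown here, the only measured step, a 5.7-fold higher number from compound 1 to compound 2 (0.75 log units; beyond the scatter), is modest but beyond the scatter. It replaces 3-methoxyphenyl with 2,5-dimethylphenyl.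

Compound 3 `COc1cc(OC)cc(N2CCN(C(=O)c3oc(C)nc3-c3ccccc3F)CC2)c1` has 3,5-dimethoxyphenyl in place of 2,5-dimethylphenyl on an amine nitrogen in a ring. Among the measured compounds shown here, the step to it roughly reverses the measured one, although no measured compound shows what the second methoxy group does. A step somewhat smaller than the measured one is therefore expected, towards a lower number. The estimated change is a 3.2-fold lower number from compound 2 to compound 3 (0.50 log units; beyond the scatter). Compound 3 is expected at 100 nM, with an estimated range of 30 nM to 320 nM.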

Compound 3, half-maximal inhibitory concentration: 10.3 nM
Compound 3: middle estimate off by 9.7-fold (0.99 log units), on the high side, and the stated range ends above it.
By their numbers in this assay, from the lowest: compound 3; then compound 1; then compound 2.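

In this assay the second methoxy group now has a reading of its own: methoxy in place of hydrogen on an aromatic carbon gives a 5.4-fold lower number from compound 1 to compound 3 (0.74 log units; beyond the scatter) and so improves on the 3-methoxyphenyl group rather than merely matching it. The exchange of 2,5-dimethylphenyl for 3,5-dimethoxyphenyl gives a 31-fold lower number from compound 2 to compound 3 (1.49 log units; beyond the scatter) and is a large step, which shows that the aryl group on the ring nitrogen spans a wider range than a 5.7-fold higher number from compound 1 to compound 2 (0.75 log units; beyond the scatter) alone suggested. Nothing available here explains why the added methoxy group lowers the number.

Still open, on these data alone, is whether methoxy itself matters at these places, since ethoxy, hydroxy or amino groups in its stead would test that. Also open, as far as these compounds go, is whether a third methoxy group on the aryl ring would lower the number further.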